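Sulfonylurea series on rat aorta: chloro versus methyl

The source may report more compounds than this note shows. Statements on the series, on what has been measured and on what is new or still open speak of the compounds shown alone.

Compound 1, `COc1ccc(OC)c(CNC(=O)NS(=O)(=O)c2ccc(Cl)cc2)c1`: in a functional assay on thoracic aorta (Rattus norvegicus, strain Wistar), with a stated time of 15 min (on this read-out lower numbers stand for an effect already at smaller amounts and higher numbers for an effect only at larger amounts of compound), compound 1 gives > 300000 nM, which is a limit of the assay and not a number.
Compound 2, `COc1ccc(OC)c(CNC(=O)NS(=O)(=O)c2ccc(C)cc2)c1`: in this assay compound 2 gives > 300000 nM, again a limit.
Among the measured compounds shown here, compound 3, `CC(NC(=O)N(C)S(=O)(=O)c1ccc(Cl)cc1)c1ccccc1OCc1ccccc1`: in this assay compound 3 gives 38400 nM, the only number in the set.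

From compound 1 to compound 2 the change is methyl in place of chloro on an aromatic carbon. Its step, a step that the two limits leave unreadable from compound 1 to compound 2, cannot be read, since the limit of > 300000 nM in this assay, at which 2 of the 3 values shown sit, covers both ends of the pair. The difference between the core of compound 1 and the core of compound 3 is not broken down here.

Compound 4, `Cc1ccc(S(=O)(=O)N(C)C(=O)NC(C)c2ccccc2OCc2ccccc2)cc1`, is not yet measured. It differs from compound 3 by methyl in place of chloro on an aromatic carbon, the same change as from compound 1 to compound 2. That earlier step gives no size to build on, so the expectation for compound 4 rests on compound 3 alone and its value 38400 nM. The estimated step is a 1.3-fold higher number from compound 3 to compound 4 (0.11 log units; within the scatter), small. Compound 4 is expected to give about 50000 nM, between 15000 nM and 200000 nM.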

Compound 4, half-maximal effective concentration: 31000 nM
For compound 4 the middle estimate is 1.6-fold (0.21 log units) above the measured one, and the stated range covers the measured number.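

In this assay, methyl in place of chloro on the core of compound 3 gives a 1.2-fold lower number from compound 3 to compound 4 (0.09 log units; within the scatter), so on this core the 4-chlorophenyl and 4-methylphenyl forms cannot be told apart. Among the compounds shown here, this is the only readable instance of the change, since on the core of compound 1 the step from compound 1 to compound 2 cannot be read, with a limit of the assay and not a number at both ends: the limit of > 300000 nM in this assay, at which 2 of the 4 values shown sit. The pair on the core of compound 3 therefore shows that the change is tolerated there, but it does not show that a step of this size carries over from one core to the other, as there is no second size to set beside it.

Going by these compounds, it remains open whether another group in the same place on the aromatic ring, such as an amine, a carboxylic acid or a longer chain, would give a step beyond the scatter. The compounds shown also do not separate the several differences between the core of compound 1 and the core of compound 3.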